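A few compounds are considered here, and "the series" means these few. Any claim that something is new, unique, unknown or untested is made for them only; others in the source may bear on it.

Measured so far:

Compound 1 `C/C(=C/CC/C(C)=C/CC/C(C)=C/C(=O)C/C(C)=C/Cc1cc(O)cc(C)c1O)CO` — in a functional assay on HepG2 cells (Homo sapiens) for cytotoxicity (on this read-out higher numbers stand for lower toxicity in this test and lower numbers for higher toxicity in this test), compound 1 gives > 10 ug/mL, which is a limit of the assay rather than a number.
Compound 2 `C/C(=C/CC/C(C)=C/CC/C(C)=C\C(=O)C/C(C)=C/Cc1cc(O)cc(C)c1O)CO` — in this assay compound 2 gives > 10 ug/mL, again a limit of the assay.
Compound 3 `C/C(=C\C(=O)C/C(C)=C/Cc1cc(O)cc(C)c1O)CC/C=C(\C)Cc1cc(C)co1` — in this assay compound 3 gives > 10 ug/mL, also a limit of the assay.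

Compound 3 therefore stands where every compound shown stands: at the same limit, with no number of its own, as the limit of > 10 ug/mL in this assay, at which 3 of the 3 values shown sit, sets out. The next compound, compound 4 `C/C(=C/C(=O)C/C(C)=C/Cc1cc(O)cc(C)c1O)CC/C=C(\C)Cc1cc(C)co1`, differs from compound 3 only in the way one double bond is drawn: the two compounds have the same atoms and bonds and differ only in configuration as drawn: 1 of 3 stereo elements differ; a double bond is drawn E in compound 3 and Z in compound 4.

Two measured steps are relevant. The step that the two limits leave unreadable from compound 1 to compound 2 is the closest match, since the fact that compounds 1 and 2 differ only in the configuration as drawn makes it the same kind of change, but its size cannot be read, as both ends sit at the limit. The step that the two limits leave unreadable from compound 1 to compound 3 is likewise unreadable for the same reason. Neither gives a size or a direction, and nothing shown suggests a change in configuration moves the read-out beyond the scatter. Compound 4 is therefore expected to remain at the limit, with a step that the limit leaves unreadable from compound 3 to compound 4 no larger than the scatter. The estimate for compound 4 in this assay is 15 ug/mL, within 8 ug/mL to 40 ug/mL.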

Compound 4, concentration lethal to 50% of the cells: > 10 ug/mL
Compound 4: no number, only a limit (the forecaster's own chance of this, stated with the estimate: 85%); the middle value does not contradict the limit.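

In this assay compound 4 gives > 10 ug/mL as a limit of the assay and not a number. Compounds 2 and 3 also sit at limits, so neither new step to compound 4 can be read. In this assay the compounds shown leave open whether the double-bond configuration or the 4-methylfuran-2-yl group changes the cytotoxicity at all.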